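This account rests on a few compounds, and the source may have more. Where it says the series, first, only, none or still open, it means among the compounds named here.

Measured so far:
compound 1 `Cc1cc(/C=C2\S/C(=N\c3ccccc3)N(C3CCCCC3)C2=O)c(C)n1-c1ccccc1` — > 200000 nM
compound 2 `Cc1cc(/C=C2\S/C(=N\c3ccccc3)N(C3CCCCC3)C2=O)c(C)n1-c1ccc(C(F)(F)F)cc1` — > 170000 nM

In an ADME assay on L6 cells (Rattus norvegicus) for cytotoxicity, read by microscopy and resazurin assay, with a stated time of 72 h (on this read-out higher numbers stand for an effect only at larger amounts of compound and lower numbers for an effect already at smaller amounts), compound 1 gives > 200000 nM, which is a limit of the assay rather than a number. Compound 2 likewise gives > 170000 nM, also a limit. The step that the two limits leave unreadable from compound 1 to compound 2 therefore cannot be read in size, since both ends sit at limits, as the limit of > 170000 nM in this assay, at which 1 of the 2 values shown sits, and the limit of > 200000 nM in this assay, at which 1 of the 2 values shown sits, show. Compound 3 `Cc1cc(/C=C2\S/C(=N\c3ccccc3)N(C3CCCCC3)C2=O)c(C)n1-c1cccc(C(F)(F)F)c1` differs from compound 1 by trifluoromethyl in place of hydrogen on an aromatic carbon. Within the data shown here, the only measured step that bears on this change is a step that the two limits leave unreadable from compound 1 to compound 2, and it yields no readable size, so nothing in the data points to a shift beyond the usual scatter in this assay in either direction. Compound 3 is accordingly expected to come out at a limit as well, with an estimate of 200000 nM and a range from 100000 nM to 400000 nM. The expected step is a number no higher from compound 1 to compound 3 (the limit leaves the size open).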

Compound 3, half-maximal effective concentration: > 170000 nM
Compound 3 gave a limit, no number (the forecaster's own chance of this, stated with the estimate: 85%); the middle value does not contradict the limit.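

Compound 3 gives > 170000 nM, a limit and not a number. Among these compounds, with compound 1, compound 2 and compound 3 all at limits, no step among them can be read. The compounds shown leave open whether trifluoromethyl in place of hydrogen, or 3-(trifluoromethyl)phenyl in place of 4-(trifluoromethyl)phenyl, changes anything in this assay.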